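Methoxy for tert-Butyl: Expected Cytotoxicity of Compound 4

A few compounds are considered here, and "the series" means these few. Any claim that something is new, unique, unknown or untested is made for them only; others in the source may bear on it.

Measured so far:
compound 1 `Cc1cc(NC(=O)Nc2ccc(C(C)(C)C)cc2)c2ccccc2n1`: > 25000 nM
compound 2 `Cc1cc(NC(=O)Nc2ccc3[nH]cnc3c2)c2ccccc2n1`: > 25000 nM
compound 3 `Cc1cc(NC(=O)Nc2cc(F)cc(F)c2)c2ccccc2n1`: > 25000 nM

All three values come from an ADME assay on HEK293 cells (Homo sapiens) for cytotoxicity, with a stated time of 72 h; on this read-out higher numbers stand for an effect only at larger amounts of compound and lower numbers for an effect already at smaller amounts. Each of them is a limit of the assay rather than a number, as the limit of > 25000 nM in this assay, at which 3 of the 3 values shown sit, shows. Going by the values given here, compound 1 therefore stands at that limit, level with the other two, and no step between measured compounds that differ in a single place is available. Compound 4 `COc1ccc(NC(=O)Nc2cc(C)nc3ccccc23)cc1` differs from compound 1 by methoxy in place of tert-butyl on an aromatic carbon. Nothing among the three measured compounds points to a change in this assay, so compound 4 is expected to remain at the limit, with a step from compound 1 of a step that the limit leaves unreadable from compound 1 to compound 4, none beyond the usual scatter. The estimate for compound 4 is 30000 nM, within 20000 nM to 60000 nM.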

Compound 4, half-maximal effective concentration: > 25000 nM
Compound 4 gave a limit, no number; the forecaster's own chance of this, stated with the estimate: 85%; the middle value lies beyond the limit too.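

Compound 1 and compound 4 each gave a limit rather than a number, so no step between them can be read: the limit of > 25000 nM in this assay, at which 4 of the 4 values shown sit.

The compounds shown leave open whether methoxy and tert-butyl differ at all in their effect on these cells.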